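A few compounds are considered here, and "the series" means these few. Any claim that something is new, unique, unknown or untested is made for them only; others in the source may bear on it.

Compound 1 `COc1cc(-c2nnc3n2NC(c2ccco2)C(C(=O)C2CC2)S3)cc(OC)c1OC` carries a cyclopropyl group on a carbonyl carbon attached to the shared core. In a functional assay on HepG2 cells (Homo sapiens) for cytotoxicity, read by MTT assay, with a stated time of 48 h (a lower number here means a stronger inhibitor, a higher number a weaker inhibitor), compound 1 gives > 100000 nM, which is a limit of the assay rather than a number. Compound 2 `COc1cc(-c2nnc3n2NC(c2ccco2)C(C(=O)c2ccc(C(F)(F)F)cc2)S3)cc(OC)c1OC` differs from compound 1 only in having 4-(trifluoromethyl)phenyl in place of cyclopropyl on that carbonyl carbon. In this assay compound 2 gives > 100000 nM, again a limit. The step that the two limits leave unreadable from compound 1 to compound 2 is therefore not readable, since both values sit at the limit of > 100000 nM in this assay, at which 2 of the 2 values shown sit.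

Compound 3 `COc1cc(-c2nnc3n2NC(c2ccco2)C(C(=O)c2ccc(Cl)cc2)S3)cc(OC)c1OC` is the compound not yet measured. It differs from compound 1 by 4-chlorophenyl in place of cyclopropyl on a carbonyl carbon. Going by the values given here, the only measured step that resembles this change, from compound 1 to compound 2, gives no readable size, so no movement beyond the scatter can be expected for this assay in either direction. Compound 3 is estimated to give 150000 nM, with a range of 50000 nM to 500000 nM, most likely reported as a limit; the expected step is a step that the limit leaves unreadable from compound 1 to compound 3.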

Compound 3, half-maximal inhibitory concentration: 78600 nM
Compound 3: the middle estimate sits 1.9-fold (0.28 log units) above what was measured, within the range that was stated.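

In this assay, going by these compounds alone, compound 3, with 4-chlorophenyl on the carbonyl carbon, gives 78600 nM, the first reading at this position that is a number and not a limit. Against the earlier compounds this gives an at least 1.2-fold lower number from compound 1 to compound 3 (0.10 log units; that floor lies within the scatter) and an at least 1.2-fold lower number from compound 2 to compound 3 (0.10 log units; that floor lies within the scatter), so both are only floors and neither shows a firm gain, while the step between compound 1 and compound 2 cannot be read. The true size of these steps stays hidden, and the ceiling of the assay explains why: the limit of > 100000 nM in this assay, at which 2 of the 3 values shown sit.

Going by these compounds, whether an amine or a carboxylic acid in place of chloro on that aromatic carbon would move the number beyond the scatter in this assay stays open. Also open, on these data alone, is what a longer chain in place of cyclopropyl on the carbonyl carbon would do.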